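From 2-chlorophenyl to 4-chlorophenyl: an unmeasured isomer

The source may report more compounds than this note shows. Statements on the series, on what has been measured and on what is new or still open speak of the compounds shown alone.

Compound 1 (`O=c1ccc2cc(OCc3cc(-c4ccccc4Cl)no3)ccc2o1`) has no single number to stand on in a functional assay on HCT-116 cells (Homo sapiens) for cytotoxicity, read by MTT assay, with a stated time of 48 h; on this read-out higher numbers stand for weaker inhibition and lower numbers for stronger inhibition ("not determined" (no result reported)). Compound 3 (`COc1cccc(-c2cc(COc3ccc4oc(=O)ccc4c3)on2)c1`) has none either ("not determined" (no result reported)). Only compound 2 (`O=c1ccc2cc(OCc3cc(-c4ccc5ccccc5c4)no3)ccc2o1`) carries a number (55900 nM). Compound 4 (`O=c1ccc2cc(OCc3cc(-c4ccc(Cl)cc4)no3)ccc2o1`) has the same atoms as compound 1, joined differently (4-chlorophenyl in place of 2-chlorophenyl on an aromatic carbon): 4-chlorophenyl in place of 2-chlorophenyl on an aromatic carbon. For the measured compounds named here, no measured step shows what such a change does, so no step beyond the usual scatter is expected in this assay and neither direction is favoured. The estimate therefore rests on compound 2 alone at 55900 nM and stays wide. Compound 4 is expected at 40000 nM (estimated range 15000 nM to 100000 nM).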

Compound 4, half-maximal inhibitory concentration: 55800 nM
For compound 4 the middle estimate is 1.4-fold (0.14 log units) below the measured one; the range from low to high includes it.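

No step can be read between compound 1 and compound 4 in this assay. The compounds shown leave open what 4-chlorophenyl in place of 2-chlorophenyl does to this read-out, and nothing shown bears on a cause.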